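The source may report more compounds than this note shows. Statements on the series, on what has been measured and on what is new or still open speak of the compounds shown alone.

Compound 1 `COCCOC(=O)C(O)Cn1cnc2c(N)ncnc21`: > 400 ug/mL. Compound 2 `CC(C)(C)OC(=O)C(O)Cn1cnc2c(N)ncnc21`: > 400 ug/mL.

In a functional assay on Vero cells (Chlorocebus sabaeus) for cytotoxicity (a higher number here means that more compound is tolerated, a lower number that less compound is tolerated), compound 1 gives only a limit of the assay, > 400 ug/mL. Compound 2 likewise gives only a limit, > 400 ug/mL. The step that the two limits leave unreadable from compound 1 to compound 2 cannot be read, since both values sit at the limit (the limit of > 400 ug/mL in this assay, at which 2 of the 2 values shown sit). Compound 3 `CCC(C)OC(=O)C(O)Cn1cnc2c(N)ncnc21` differs from compound 2 by sec-butyl in place of tert-butyl on an oxygen next to a carbonyl group. Among the measured compounds shown here, no measured step shows how this change acts, so no shift beyond the scatter is expected. The expected step is a number no higher from compound 2 to compound 3 (the limit leaves the size open). Compound 3 is therefore estimated at 400 ug/mL, within 200 ug/mL to 800 ug/mL, most likely again only a limit.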

Compound 3, minimum cytotoxic concentration: > 400 ug/mL
Compound 3 gave a limit, no number (the forecaster's own chance of this, stated with the estimate: 85%); the middle value lies on the limit itself.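

No step can be read among compound 1, compound 2 and compound 3 in this assay, since all their values are limits and not numbers: the limit of > 400 ug/mL in this assay, at which 3 of the 3 values shown sit.

The compounds shown leave open whether exchanging these groups changes the tolerated concentration at all.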